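Phenyl substituent variation and maximal response in the series

The source may report more compounds than this note shows. Statements on the series, on what has been measured and on what is new or still open speak of the compounds shown alone.

Compound 2 `N=C(NCCCc1c[nH]cn1)NCCC(c1cccc(C(F)(F)F)c1)c1ccccn1`, in a functional assay on cardiac atrium for agonist activity at histamine H2 receptor (Cavia porcellus) (on this read-out lower numbers stand for smaller maximal responses and higher numbers for larger maximal responses), gives 1. It stands highest of the two numbers measured, with compound 1 `N=C(NCCCc1c[nH]cn1)NCCC(c1ccc(C(F)(F)F)cc1)c1ccccn1` nearest: compound 1 gives 0.9 in this assay, and the step a number 0.10 higher from compound 1 to compound 2 (within the scatter) lies within the scatter, so the two compounds are not separable on this read-out. Compound 3 `N=C(NCCCc1c[nH]cn1)NCCC(c1ccccn1)c1ccccc1F` is not yet measured in this assay. It differs from compound 2 as follows: 2-fluorophenyl in place of 3-(trifluoromethyl)phenyl on a saturated chain carbon bound to an aromatic carbon and a saturated chain carbon. For the measured compounds named here, the only measured step that bears on this change is the one between compound 1 and compound 2, which also alters the substituted phenyl on the same saturated chain carbon; that step was within the scatter. On that basis no step beyond the scatter is expected in this assay, in either direction, and the step a number 0.050 lower from compound 2 to compound 3 (within the scatter) is the estimated change. Compound 3 is accordingly expected to give about 0.95 in this assay, within a range from 0.75 to 1.05.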

Compound 3, intrinsic activity: the largest response reached, as a fraction of the reference agonist's: 1
For compound 3 the middle estimate is 0.050 below the measured one; the measured number falls inside the stated range.
By their numbers in this assay, from the lowest: compounds 1, 2 and 3 (each within the scatter of the next).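

In this assay, 2-fluorophenyl in place of 3-(trifluoromethyl)phenyl on the saturated chain carbon gives no change at the digits printed from compound 2 to compound 3 (within the scatter), and this change brings the group from 10 heavy atoms (3 fluorine) to 7 heavy atoms (1 fluorine). Against the 4-(trifluoromethyl)phenyl group at the same carbon, the change gives a number 0.10 higher from compound 1 to compound 3 (within the scatter), so all three substituted phenyl groups shown remain inseparable on this read-out, and trifluoromethyl is not required for a maximal response of this size. No measurement is available here that offers an explanation for this result.

All three compounds carry fluorine on this phenyl, so the compounds shown leave open whether an unsubstituted phenyl, or a phenyl bearing an amine or a carboxylic acid, would stay within the scatter in this assay. They also leave open how a longer chain at this carbon would behave.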